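The source may report more compounds than this note shows. Statements on the series, on what has been measured and on what is new or still open speak of the compounds shown alone.

Notes on the series. The shared core is carried by compound 1 `C#CCCOC(=O)c1ccc(C(CC)(CC)c2ccc(C#CC(O)(CC)CC)c(C)c2)n1CC` and compound 2 `CCn1c(C(=O)On2nnc3ccccc32)ccc1C(CC)(CC)c1ccc(C#CC(O)(CC)CC)c(C)c1`, both read in an assay on cells for agonist activity at vitamin D3 receptor (Homo sapiens), read by microscopy; on this read-out lower numbers stand for an effect already at smaller amounts and higher numbers for an effect only at larger amounts of compound. For compound 1 the read-out stops at the limit > 50 nM. For compound 2 the read-out likewise stops at the limit > 50 nM. The step that the two limits leave unreadable from compound 1 to compound 2 is therefore of unreadable size, and the limit of > 50 nM in this assay, at which 2 of the 3 values shown sit, is all that these two compounds offer. Going by the values given here, compound 3 `CCn1cc(C(CC)(CC)c2ccc(C#CC(O)(CC)CC)c(C)c2)cc1C(=O)NCC(=O)OC` is the one member with a number: in this assay compound 3 gives 288 nM, the sole numeric value here.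

Compound 4 `CCn1cc(C(CC)(CC)c2ccc(C#CC(O)(CC)CC)c(C)c2)cc1C(=O)N[C@@H](C)CO` differs from compound 3 by 1-(hydroxymethyl)ethyl in place of (methoxycarbonyl)methyl on an amide-type nitrogen. Among the compounds with values here, no measured step touches this amide substituent, and the single measured step is unreadable. No shift beyond the scatter can be drawn from the data, so the step of a 1.0-fold higher number from compound 3 to compound 4 (0.02 log units; within the scatter) is estimated near zero, with a wide range to reflect the absence of any bearing step. Compound 4 is accordingly expected to give 300 nM in this assay, between 100 nM and 900 nM.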

Compound 4, half-maximal effective concentration: 7.33 nM
Estimate against measurement, compound 4: 41-fold (1.61 log units) above; measured number outside the range, below it.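

In this assay, going by these compounds alone, putting 1-(hydroxymethyl)ethyl in place of (methoxycarbonyl)methyl on the amide-type nitrogen gives a 39-fold lower number from compound 3 to compound 4 (1.59 log units; beyond the scatter), the first readable step; the earlier step, between two limits, cannot be read. This amide substituent is thus a place where a change of one group moves the read-out well beyond the scatter, and the entering group carries a hydrogen-bond donor and a defined stereocentre where the leaving group has neither. No measured property of either group is available to account for the step.

Which feature of the entering group carries the step stays open, as the hydroxyl, the methyl branch and the stereocentre change together here. Also open, from the compounds shown here alone, is how a carboxylic acid or an amine on this amide chain would read.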